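The compounds below may be only part of what the source reports. "The series", "measured", "known", "first", "only" and "open" are said of these compounds alone.

Measured in a functional assay on MCF7 cells (Homo sapiens) for inhibition, read by fluorescence, with a stated time of 72 h; on this read-out higher numbers stand for weaker inhibition of growth and lower numbers for stronger inhibition of growth:
compound 1 `CCCCc1cc2nn(-c3ccccc3)cc2cn1` gives 13300 nM
compound 2 `CCCCc1cc2nn(-c3ccccc3)cc2c(C)n1` gives 11100 nM
compound 3 `CCCCCc1cc2nn(-c3ccccc3)cc2c(C)n1` gives 17000 nM

These three numbers lie close together. The step of a 1.2-fold lower number from compound 1 to compound 2 (0.08 log units; within the scatter) comes from a methyl in place of hydrogen on an aromatic carbon, and the step of a 1.5-fold higher number from compound 2 to compound 3 (0.19 log units; within the scatter) from a methyl in place of hydrogen on a saturated chain carbon, four bonds along the chain from an aromatic carbon. Compound 1 and compound 3 differ by both of these changes, and their two values lie within the scatter of each other.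

Compound 4 `c1ccc(-c2cc3nn(-c4ccccc4)cc3cn2)cc1` has not been measured in this assay. It differs from compound 1 by phenyl in place of butyl on an aromatic carbon. Neither measured step touches the butyl chain as a whole or brings in a ring, so they give no direct guide to this change; they only show that small additions around the shared core kept the read-out in this assay within its scatter. Among the compounds with values here, with no closer precedent, the expected step is one no larger than the scatter, a 1.0-fold lower number from compound 1 to compound 4 (0.01 log units; within the scatter), though the uncertainty is wide. Compound 4 is therefore estimated at 13000 nM, within a range from 3000 nM to 50000 nM.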

Compound 4, concentration for 50% growth inhibition: 4800 nM
The estimate for compound 4 lay 2.7-fold (0.43 log units) above the measured number, within the range that was stated.
By their numbers in this assay, from the lowest: compound 4; then compounds 2, 1 and 3 (each within the scatter of the next).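

Replacing butyl with phenyl on the aromatic carbon next to the ring nitrogen gives a 2.8-fold lower number from compound 1 to compound 4 (0.44 log units; beyond the scatter) in this assay. Unlike the two earlier steps, this change moves the read-out beyond the scatter, so this position can respond to a change in the group it carries, although the effect is modest. The swap replaces an open chain with an aromatic ring and also changes the number of heavy atoms, and no measurement here explains the gain.

This single step cannot separate the effect of having a ring from that of the group's size, and a saturated ring such as cyclohexyl would bear on that question. It also leaves open whether a phenyl carrying a methoxy group, or a pyridine ring in its place, would give a different read-out.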